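This account rests on a few compounds, and the source may have more. Where it says the series, first, only, none or still open, it means among the compounds named here.

Compound 1 `COc1c(Br)cccc1C(=O)Nc1ccc(Sc2nc3ccccc3s2)c(Cl)c1` was tested in an assay on isolated protein for inhibition of thiosulfate sulfurtransferase (Homo sapiens), with a stated time of 60 min, in the absence of a further agent; a lower number here means a stronger inhibitor, a higher number a weaker inhibitor. In that test compound 1 gives > 100000 nM, which is a limit of the assay rather than a measured number. Compound 2 `O=C(Nc1cccc(Cl)c1)c1ccccc1O`, a smaller amide built on the same kind of carbonyl-to-nitrogen link, was tested in this assay as well. Here compound 2 gives > 100000 nM, again only a limit. Both results therefore rest at one and the same place, as recorded in the limit of > 100000 nM in this assay, at which 2 of the 2 values shown sit. Compound 3 `O=C(Nc1ccc(Sc2nc3ccccc3s2)c(Cl)c1)c1cc(Br)cc(Br)c1O` has not yet been measured. It differs from compound 1 in a single place: a group of 9 heavy atoms (6 carbon, 1 oxygen, 2 bromine; one six-membered aromatic ring of carbon only) in place of a group of 9 heavy atoms (7 carbon, 1 oxygen, 1 bromine; one six-membered aromatic ring of carbon only), on a carbonyl carbon. Among the measured compounds shown here, no step between two measured compounds is available here, so any expectation rests only on the fact that every known value sits at a limit. Compound 3 is expected to give 100000 nM in this assay, with a likely range from 20000 nM to 300000 nM. The expected step of a number no higher from compound 1 to compound 3 (the limit leaves the size open) is therefore estimated as none beyond the scatter.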

Compound 3, half-maximal inhibitory concentration: > 100000 nM
Compound 3 was reported as a limit; the forecaster's own chance of this, stated with the estimate: 70%; the middle value lies on the limit itself.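

Among the compounds shown here, compound 1 and compound 3 both rest at a limit of the assay rather than at a measured number, so no step between them can be read. All the results shown sit at the same place: the limit of > 100000 nM in this assay, at which 3 of the 3 values shown sit. The compounds shown leave open which structures, if any, would give a measurable number in this assay.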